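One Stereocentre Changed, Starting From a Limit

A few compounds are considered here, and "the series" means these few. Any claim that something is new, unique, unknown or untested is made for them only; others in the source may bear on it.

Compound 1 `CC(C)(C)[Si](C)(C)O[C@@H]1CCCO[C@@H]1CO`: > 100000 nM
Compound 2 `O=C1COC[C@H]2OCCC[C@@H]2O1`: > 100000 nM

Both entries come from a functional assay on SW1573 cells (Homo sapiens) for antiproliferative activity, read by sulforhodamine B assay, with a stated time of 48 h; on this read-out lower numbers stand for stronger inhibition of growth and higher numbers for weaker inhibition of growth. Compound 1 reads > 100000 nM, which is a limit of the assay and not a number. Compound 2 reads > 100000 nM, which is also a limit and not a number. So compound 2 has no exact value, and the whole picture so far is the limit of > 100000 nM in this assay, at which 2 of the 2 values shown sit.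

The next compound is compound 3 `O=C1COC[C@H]2OCCC[C@H]2O1`. Its structural difference from compound 2 is small: the two compounds have the same atoms and bonds and differ only in configuration as drawn: 1 of 2 stereo elements differ; a stereocentre at a saturated ring carbon is drawn S in compound 2 and R in compound 3. Nothing leaves and nothing enters, so the two compounds differ only in how one saturated ring carbon is drawn.

For the measured compounds named here, no measured pair shows what such a change does in this assay. The expectation therefore rests on compound 2 alone, with its limit of > 100000 nM. No step beyond the usual scatter is expected, and another limit is the likeliest reading. Any number that does appear could only lie towards stronger inhibition. The expected change is an at least 1.1-fold lower number from compound 2 to compound 3 (0.04 log units; that floor lies within the scatter). The estimate for compound 3 is 90000 nM, with an expected range from 30000 nM to 100000 nM.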

Compound 3, concentration for 50% growth inhibition: > 100000 nM
Compound 3 was reported as a limit (the forecaster's own chance of this, stated with the estimate: 75%); middle value at least 1.1-fold (0.04 log units) from the limit.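

In this assay, compound 2 and compound 3 both read as a limit and not as a number, so no step can be read between them. The compounds shown leave open whether drawing that saturated ring carbon as S or as R changes growth inhibition at all, and how far any of these compounds lies past the limit.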